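This account rests on a few compounds, and the source may have more. Where it says the series, first, only, none or still open, it means among the compounds named here.

Measured so far:
Compound 1 `COCCOCCCCc1[nH]c2ccccc2c(=O)c1C` in a physicochemical assay for solubility, at pH 6.8 (on this read-out higher numbers stand for higher solubility and lower numbers for lower solubility), gives >= 100000 nM, which is a limit of the assay and not a number.
Compound 2 `Cc1c(COc2cncc(OCCC(C)(C)O)c2)[nH]c2ccccc2c1=O` gives >= 100000 nM, again a limit.
Compound 3 `Cc1c(COc2cccc(OCC3CCOCC3)c2)[nH]c2ccc(C(=O)O)cc2c1=O` gives >= 100000 nM, also a limit.

The three compounds share a core and differ in their side chains, yet none of them returns a number: all three sit at the limit of >= 100000 nM in this assay, at which 3 of the 3 values shown sit. Among the compounds with values here, compound 1 therefore stands at the upper bound of what this assay can report, with no measured step to any neighbour, and nothing in these values separates it from compound 2 or compound 3.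

Compound 4 `CCCCCCCCCc1[nH]c2ccccc2c(=O)c1C` has not yet been measured. It differs from compound 1 in one place: pentyl in place of 2-methoxyethoxy on a saturated chain carbon, four bonds along the chain from an aromatic carbon.

Within the data shown here, no step between measured compounds is available to calibrate this change. The account expects the step of an at least 5.0-fold lower number from compound 1 to compound 4 (0.69 log units; beyond the scatter) to run downward, by more than the usual scatter, bringing compound 4 out of the limit region into a range where a number is reported. From the compounds shown here alone, for compound 4 the expected value in this assay is 20000 nM, with a range from 3000 nM to 100000 nM; whether it instead reaches the limit, as compound 1 did with >= 100000 nM, remains open until the measurement is made.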

Compound 4, solubility: < 1000 nM
Compound 4 was reported as a limit (the forecaster's own chance of this, stated with the estimate: 25%); middle value at least 20-fold (1.30 log units) away from the limit.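

In this assay, the chain of compound 1 proves sensitive to what it carries at this place: pentyl in place of 2-methoxyethoxy, on a saturated chain carbon, four bonds along the chain from an aromatic carbon, gives an at least 100-fold lower number from compound 1 to compound 4 (2.00 log units; beyond the scatter). The earlier compounds could not show this, as they differ in their side chains yet all return the same limit, leaving no difference to read: the limit of >= 100000 nM in this assay, at which 3 of the 4 values shown sit. The exchange keeps the heavy-atom count and swaps only the oxygen atoms of the chain for carbon, yet this alone carries the read-out from that limit to the opposite one: the limit of < 1000 nM in this assay, at which 1 of the 4 values shown sits.

From the compounds shown here alone, the step joins two limits of the assay and not two numbers, so its true size stays unknown, and neither end of it gives a value from which a trend could be drawn. Also open, going by these compounds, is whether one ether oxygen in the chain would suffice to hold the read-out at the upper limit, and how a shorter chain or an amine at the same place would behave.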